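Adding an amino link to a compound at the limit

The source may report more compounds than this note shows. Statements on the series, on what has been measured and on what is new or still open speak of the compounds shown alone.

In a functional assay on Jurkat cells (Homo sapiens) for antiproliferative activity, read by MTT assay, with a stated time of 72 h (on this read-out higher numbers stand for weaker inhibition and lower numbers for stronger inhibition), compound 1 `COc1ccccc1-c1c(C(=O)c2cc(OC)c(OC)c(OC)c2)sc2ccccc12` gives 2900 nM. Compound 2 `COc1ccc(OC)c(-c2c(C(=O)c3cc(OC)c(OC)c(OC)c3)sc3ccccc23)c1` reads > 10000 nM, which is a limit of the assay and not a number. Compound 3 `COc1ccc(-c2c(C(=O)c3cc(OC)c(OC)c(OC)c3)sc3ccccc23)cc1C` reads > 10000 nM, which is also only a limit. Compound 4 `COc1ccc(Nc2c(C(=O)c3cc(OC)c(OC)c(OC)c3)sc3ccccc23)cc1` carries (4-methoxyphenyl)amino in place of 4-methoxy-3-methylphenyl on an aromatic carbon. The nearest guides are an at least 3.4-fold higher number from compound 1 to compound 3 (0.53 log units; beyond the scatter) and an at least 3.4-fold higher number from compound 1 to compound 2 (0.53 log units; beyond the scatter), both modest changes in the aromatic group, yet neither involves an amino link. The expected change is modest and toward stronger inhibition, an at least 1.6-fold lower number from compound 3 to compound 4 (0.22 log units; that floor lies within the scatter), although another limit remains quite possible. Compound 4 is estimated at 6000 nM, with an expected range from 1000 nM to 30000 nM.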

Compound 4, half-maximal inhibitory concentration: 3500 nM
Estimate against measurement, compound 4: 1.7-fold (0.23 log units) above; measured number inside the range.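

In this assay, placing (4-methoxyphenyl)amino at this position, two ring bonds from the ring sulfur, gives an at least 2.8-fold lower number from compound 3 to compound 4 (0.45 log units; beyond the scatter) and also an at least 2.8-fold lower number from compound 2 to compound 4 (0.45 log units; beyond the scatter). Against the 2-methoxyphenyl group, the same change gives a 1.2-fold higher number from compound 1 to compound 4 (0.08 log units; within the scatter), so a directly attached ring and an amino-linked ring can both give a measurable value here. The first two steps show only a minimum size: the limit of > 10000 nM in this assay, at which 2 of the 4 values shown sit.

From the compounds shown here alone, it remains open how an oxygen link or a methylated amine link at this position would read. Going by these compounds, whether the amine hydrogen matters also remains open.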